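Ring expansion on the amine of compound 3

The source may hold more compounds than are shown below. What is called first, only, known or untested is meant among the compounds shown, and "the series" means these compounds.

Measured so far:
- compound 1 `CC(C)=CC(=O)Nc1cc2c(N3CCc4ccccc43)ncnc2cc1O[C@@H]1CCOC1`: in a functional assay on PC-3 cells (Homo sapiens) for antiproliferative activity, read by MTT assay, with a stated time of 72 h (a higher number here means a weaker inhibitor, a lower number a stronger inhibitor), compound 1 gives 4620 nM
- compound 2 `CC/C=C/C(=O)Nc1cc2c(N3CCc4ccccc43)ncnc2cc1O[C@@H]1CCOC1`: in this assay compound 2 gives 9590 nM
- compound 3 `CN1CCN(C/C=C/C(=O)Nc2cc3c(N4CCc5ccccc54)ncnc3cc2O[C@@H]2CCOC2)CC1`: in this assay compound 3 gives 4210 nM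

Compound 3 shows the lowest of the three numbers, though its gap to compound 1 lies within the scatter, while a 2.3-fold lower number from compound 2 to compound 3 (0.36 log units; beyond the scatter). Compound 4 `CN1CCN(C/C=C/C(=O)Nc2cc3c(N4CCCc5ccccc54)ncnc3cc2O[C@@H]2CCOC2)CC1` differs from compound 3 by 1,2,3,4-tetrahydroquinolin-1-yl in place of 2,3-dihydro-1H-indol-1-yl on an aromatic carbon. Going by the values given here, none of the measured steps touches this part of the shared core: a 2.1-fold higher number from compound 1 to compound 2 (0.32 log units; beyond the scatter) and a 1.1-fold lower number from compound 1 to compound 3 (0.04 log units; within the scatter) both concern the chain on the carbonyl carbon, so the data give no guidance on swapping the amine ring. With nothing to point either way, no step beyond the scatter is expected in this assay; the estimated step is a 1.0-fold lower number from compound 3 to compound 4 (0.00 log units; within the scatter). Compound 4 is therefore expected to give about 4200 nM, within the range 1400 nM to 12600 nM.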

Compound 4, half-maximal inhibitory concentration: 9450 nM
Compound 4: the middle estimate sits 2.3-fold (0.35 log units) below what was measured; the range from low to high includes it.
By their numbers in this assay, from the lowest: compounds 3 and 1 (each within the scatter of the next); then compounds 4 and 2 (each within the scatter of the next).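

The amine ring on the shared core is not a neutral place to make a change. In this assay, 1,2,3,4-tetrahydroquinolin-1-yl in place of 2,3-dihydro-1H-indol-1-yl gives a 2.2-fold higher number from compound 3 to compound 4 (0.35 log units; beyond the scatter), a modest weakening from swapping the five-membered non-aromatic ring for the six-membered one. No measurement shown here explains this step.

From the compounds shown here alone, whether an open-chain amine such as dimethylamino would shift the number further remains open. So does whether the same ring swap gives a similar step with the 2-methylprop-1-en-1-yl chain of compound 1.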